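The compounds below may be only part of what the source reports. "The series", "measured", "known", "first", "only" and "open" are said of these compounds alone.

Among the compounds with values here, in an ADME assay on H1-HeLa cells (Homo sapiens) for cytotoxicity, read by MTT assay, with a stated time of 3 days (on this read-out lower numbers stand for higher toxicity in this test and higher numbers for lower toxicity in this test), two compounds have numbers so far. Compound 1 (`CNC(=O)c1cc(Oc2ccc3c(C)c(-c4noc(C5CC5)n4)sc3c2)ccn1`) gives 6800 nM, and compound 2 (`CCc1nc(-c2ccc(Oc3ccnc(C(=O)NC)c3)cc2)no1`) gives 43700 nM. Compound 2 therefore holds the higher of the two numbers, and its gap to compound 1 lies beyond the usual scatter, making it the less toxic of the pair in this test. The two differ in more than one place, so that gap cannot be tied to any single change.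

Compound 3 (`CNC(=O)c1cc(Oc2ccc(-c3noc(COC)n3)cc2)ccn1`) has not yet been measured. It departs from compound 2 in one place, on a saturated chain carbon bound to an aromatic carbon, where methoxy stands in place of methyl: methoxy in place of methyl on a saturated chain carbon bound to an aromatic carbon. Cut one bond further out, the same difference reads ethyl to methoxymethyl. Within the data shown here, no measured pair shows this change, so the expectation starts from compound 2 at 43700 nM, and no step beyond the scatter is expected in this assay. The estimated step is a 1.0-fold higher number from compound 2 to compound 3 (0.01 log units; within the scatter). For compound 3 the expected value is 45000 nM, with an estimated range from 18000 nM to 100000 nM.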

Compound 3, half-maximal cytotoxic concentration: 63400 nM
Estimate against measurement, compound 3: 1.4-fold (0.15 log units) below; low and high end bracket the measured number.
By their numbers in this assay, from the lowest: compound 1; then compounds 2 and 3 (each within the scatter of the next).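

In this assay, methoxy in place of methyl on a saturated chain carbon bound to an aromatic carbon gives a 1.5-fold higher number from compound 2 to compound 3 (0.16 log units; within the scatter), so in this one pair the position takes the extra oxygen without a step that can be told from the scatter. Within the data shown here, this is the first single change that can be read in the set, as the gap between compound 1 and compound 2 spans more than one place and could not be tied to any of them; here, ethyl and methoxymethyl on the shared core cannot be told apart in this test. Nothing at hand bears on why the two compounds read alike.

A single pair leaves open whether an amine, a carboxylic acid or a longer chain on the same saturated chain carbon would also stay within the scatter of compound 2 or would give a step beyond it. It also leaves open whether the same change would read alike on the core of compound 1, which has the lowest number of the set.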